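The compounds below may be only part of what the source reports. "The series", "measured", "known", "first", "only" and "open" are said of these compounds alone.

Compound 1 `CCC(/N=C(\NC#N)Nc1ccncc1)C(C)C` gave 5 mg/kg in a functional assay on the whole organism (blood, strain Wistar-Okamoto) with Rattus norvegicus as the target, with a stated time of 5 days; a higher number here means that more compound is needed for the effect, a lower number that less compound is needed.
Compound 2 `N#CN/C(=N\C1CCCCC1)Nc1ccncc1` gave 20 mg/kg.
Compound 3 `CC(C)(C)/N=C(\NC#N)Nc1ccncc1` gave 2.5 mg/kg.

Among these three, compound 3 holds the lowest number, though its gap to compound 1 is within the scatter, as a 2.0-fold lower number from compound 1 to compound 3 (0.30 log units; within the scatter) shows, while its gap to compound 2 is beyond the scatter, as an 8.0-fold lower number from compound 2 to compound 3 (0.90 log units; beyond the scatter) shows. Compound 4 `CC(C)CC(C)(C)/N=C(\NC#N)Nc1ccncc1` differs from compound 3 by isopropyl in place of hydrogen on a saturated chain carbon, two bonds along the chain from a double-bonded nitrogen. The two steps that bear on this change are a 2.0-fold lower number from compound 1 to compound 3 (0.30 log units; within the scatter), within the scatter, and an 8.0-fold lower number from compound 2 to compound 3 (0.90 log units; beyond the scatter), modest and beyond the scatter. Both concern the group on the double-bonded nitrogen, and the branched chains tert-butyl and 1-isopropylpropyl gave the lower numbers, with only the cyclohexyl of compound 2 standing apart. Compound 4 keeps a branched chain there. No step beyond the scatter is expected, and the expected step is a 1.2-fold higher number from compound 3 to compound 4 (0.08 log units; within the scatter). Compound 4 is therefore estimated at 3 mg/kg, with a range from 1.5 mg/kg to 8 mg/kg.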

Compound 4, minimum effective dose: 20 mg/kg
Beside the measured number, compound 4's estimate is 6.7-fold (0.82 log units) below it; the measured number lies above the stated range.
By their numbers in this assay, from the lowest: compounds 3 and 1 (each within the scatter of the next); then compounds 2 and 4 (each within the scatter of the next).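

On a saturated chain carbon, two bonds along the chain from a double-bonded nitrogen, isopropyl in place of hydrogen is not a neutral addition, as an 8.0-fold higher number from compound 3 to compound 4 (0.90 log units; beyond the scatter) shows. The earlier step of a 2.0-fold lower number from compound 1 to compound 3 (0.30 log units; within the scatter) had left the two branched chains apart by no more than the scatter, whereas compound 4 shows that a branched chain on that nitrogen does not by itself keep the number low. Nothing available explains this step.

As far as these compounds go, whether a methyl, an ethyl or a hydroxyl at this place would stay close to compound 3 remains open. So does whether an amine there would behave as isopropyl does.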